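The source may hold more compounds than are shown below. What is called first, only, known or untested is meant among the compounds shown, and "the series" means these compounds.

In a functional assay on A-375 cells (Homo sapiens) for activation, with a stated time of 3 days (a lower number here means that less compound is needed, a higher number that more compound is needed for the effect), compound 1 (`O=C(Nc1ccc(-c2cscn2)cc1)[C@H]1CCCN(Cc2ccc(F)c(F)c2)C1`) gives 270 nM. Among the compounds with values here, compound 2 (`O=C(Nc1ccc(-c2cscn2)cc1)C1CCCN(Cc2cc(F)cc(F)c2)C1`) gives 1500 nM, the higher of the two numerical values so far, and its distance from compound 1 lies beyond the scatter. Compound 3 (`O=C(Nc1ccc(-c2cscn2)cc1)C1CCCN(Cc2cccc(OC(F)(F)F)c2)C1`) is reported as > 20000 nM, which is a limit of the assay and not a number.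

Compound 4 (`O=C(Nc1ccc(-c2cscn2)cc1)C1CCCN(Cc2ccc3cn[nH]c3c2)C1`) has not yet been measured. It carries 1H-indazol-6-yl in place of 3,5-difluorophenyl on a saturated chain carbon bound to an amine nitrogen in a ring, so that 3,5-difluorobenzyl becomes (1H-indazol-6-yl)methyl: 1H-indazol-6-yl in place of 3,5-difluorophenyl on a saturated chain carbon bound to an amine nitrogen in a ring. Within the data shown here, no measured pair shows a comparable exchange, so the expectation starts from compound 2 at 1500 nM and stays deliberately broad. The expected change is a 1.7-fold higher number from compound 2 to compound 4 (0.22 log units; within the scatter), a step not expected to lie beyond the scatter in this assay. For compound 4 the estimated value is 2500 nM, with an expected range from 400 nM to 15000 nM.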

Compound 4, half-maximal effective concentration: > 20000 nM
Compound 4 gave a limit, no number; the forecaster's own chance of this, stated with the estimate: 15%; middle value at least 8.0-fold (0.90 log units) away from the limit.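

In this assay, within the data shown here, the exchange at this place, on a saturated chain carbon bound to an amine nitrogen in a ring, gives the first step that can be read there: an at least 13-fold higher number from compound 2 to compound 4 (1.12 log units; beyond the scatter) on going to 1H-indazol-6-yl from 3,5-difluorophenyl. It shows that this place does not accept every aromatic group, since the entering group adds a five-membered aromatic ring with its hydrogen-bond donor and acceptor and the number climbs beyond the scatter. From the compounds shown here alone, the value of compound 4 is a limit of the assay and not a number, and the true size of the step stays unknown: the limit of > 20000 nM in this assay, at which 2 of the 4 values shown sit.

The compounds shown do not separate the added five-membered ring from the donor and acceptor it carries. Going by these compounds, how a pyridinyl or an aminophenyl group would read at this place also remains open.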